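This account rests on a few compounds, and the source may have more. Where it says the series, first, only, none or still open, it means among the compounds named here.

Compound 1 `CCc1ccc(-c2nc3ccccn3c2Sc2ccccc2)cc1` gives > 100000 nM as a limit
Compound 2 `Clc1ccc2nc(-c3ccccc3)c(Sc3ccccc3)n2c1` gives > 100000 nM as a limit
Compound 3 `CS(=O)(=O)c1ccc(-c2nc3ccccn3c2Sc2cccc3ccccc23)cc1` gives 83200 nM as a number

All three values come from an ADME assay on HEK293 cells (Homo sapiens) for inhibition, read by MTT assay, with a stated time of 48 h (a lower number here means a stronger inhibitor, a higher number a weaker inhibitor), and they leave little to compare. Compound 1 gives > 100000 nM here, which is a limit of the assay and not a number. Its position is a shared one, with the limit of > 100000 nM in this assay, at which 2 of the 3 values shown sit, as all that can be said of it. Compound 2 likewise gives > 100000 nM as a limit. Compound 3 gives 83200 nM as a true number. A true number cannot be ranked precisely against a limit.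

The next compound, compound 4 `Clc1ccc(-c2nc3ccccn3c2Sc2ccccc2)cc1` differs from compound 1 in one place, chloro in place of ethyl on an aromatic carbon with chloro in place of ethyl on an aromatic carbon, para to a large group, so that 4-ethylphenyl becomes 4-chlorophenyl. Among the compounds with values here, no two measured compounds differ in one place alone, so no measured step gives a size for this change. In this assay no shift beyond the scatter is expected in either direction, and another limit is likely. Within the data shown here, compound 3 at 83200 nM is the only true number so far. The estimated a number no higher from compound 1 to compound 4 (the limit leaves the size open) is therefore expected to be small. The expected value for compound 4 is 100000 nM with an estimated range from 50000 nM to 200000 nM as its likely span.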

Compound 4, half-maximal inhibitory concentration: > 100000 nM
Compound 4: no number, only a limit; the forecaster's own chance of this, stated with the estimate: 70%; the middle value lies on the limit itself.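

In this assay compound 4 gives > 100000 nM, which is a limit and not a number. Within the data shown here, compound 1 also gives only a limit, so no step between compound 1 and compound 4 can be read. The compounds shown leave open whether chloro in place of ethyl changes inhibition in this assay at all, and by how much.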